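The source may report more compounds than this note shows. Statements on the series, on what has been measured and on what is new or still open speak of the compounds shown alone.

Three compounds share one core and differ in the group carried on the sulfonyl sulfur of the ring sulfonamide. Compound 1 `COc1cc2c(cc1N1C[C@@H](C)N(C)[C@@H](C)C1)N(S(=O)(=O)c1ccc3ccccc3c1)CC2` gives 39.8 nM in a functional assay for agonist activity at growth hormone secretagogue receptor type 1 (Homo sapiens), read by FLIPR; a higher number here means that more compound is needed for the effect, a lower number that less compound is needed. Compound 2 `COc1cc2c(cc1N1C[C@@H](C)N[C@@H](C)C1)N(S(=O)(=O)Cc1cccc(I)c1)CC2` gives 31.6 nM in this assay, and compound 3 `COc1cc2c(cc1N1C[C@@H](C)N[C@@H](C)C1)N(S(=O)(=O)CCc1ccccc1Cl)CC2` gives 5.01 nM. Compound 3 therefore holds the lowest number of the three: compound 2 is closest to it, compound 1 furthest. Among the measured compounds shown here, the one step that runs between neighbours, a 6.3-fold lower number from compound 2 to compound 3 (0.80 log units; beyond the scatter), went with a 2-chlorobenzyl group in place of a 3-iodophenyl group on the chain carbon bound to the sulfonyl sulfur.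

Compound 4 `COc1cc2c(cc1N1C[C@@H](C)N[C@@H](C)C1)N(S(=O)(=O)c1ccc(-c3ccon3)s1)CC2` takes the step further: 5-(1,2-oxazol-3-yl)thiophen-2-yl in place of 2-(2-chlorophenyl)ethyl on a sulfonyl sulfur. For the measured compounds named here, no measured step covers a switch from a chain-linked aromatic ring to an aromatic ring bound straight to the sulfonyl sulfur, so the change from compound 2 to compound 3 is the only guide, and it was modest. Compound 1 and compound 2, both without that chain, sit higher than compound 3. Compound 4 is therefore expected to move back upward, estimated at 20 nM with a range from 5 nM to 80 nM, a step of a 4.0-fold higher number from compound 3 to compound 4 (0.60 log units; beyond the scatter).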

Compound 4, half-maximal effective concentration: 2.51 nM
For compound 4 the middle estimate is 8.0-fold (0.90 log units) above the measured one; the measured number lies below the stated range.
By their numbers in this assay, from the lowest: compounds 4 and 3 (each within the scatter of the next); then compounds 2 and 1 (each within the scatter of the next).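

At this place on the sulfonyl sulfur, a group joined through an aromatic ring with no chain can do as well as a chain-linked one in this assay, with a 2.0-fold lower number from compound 3 to compound 4 (0.30 log units; within the scatter). The same group also gives a 13-fold lower number from compound 2 to compound 4 (1.10 log units; beyond the scatter), so a low number does not depend on having a chain: compound 2 carries a chain-linked ring and still stands clearly higher than compound 4. No measured evidence explains why the two-ring 5-(1,2-oxazol-3-yl)thiophen-2-yl group does so well here.

The compounds shown leave open how much of this result rests on the 1,2-oxazol-3-yl ring and how much on the thiophen-2-yl ring. A thiophen-2-yl carrying a carboxylic acid or an amine in place of the 1,2-oxazol-3-yl ring would help to separate the two.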